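The source may hold more compounds than are shown below. What is called first, only, known or untested is meant among the compounds shown, and "the series" means these compounds.

In a functional assay on MCF7 cells (Homo sapiens) for antiproliferative activity, read by MTT assay, with a stated time of 72 h (on this read-out higher numbers stand for weaker inhibition and lower numbers for stronger inhibition), compound 3 `O=C1COc2ccc(-c3cnc(Cl)c(NS(=O)(=O)c4ccc(F)cc4)c3)cc2N1c1ccc(F)cc1` gives 32600 nM. Compound 2 `COc1ccc(N2C(=O)COc3ccc(-c4cnc(Cl)c(NS(=O)(=O)c5ccc(F)cc5)c4)cc32)cc1` gives 36000 nM, within the scatter of compound 3, while compound 1 `COc1ncc(-c2ccc3c(c2)N(c2ccc(C)cc2)C(=O)CO3)cc1NS(=O)(=O)c1ccc(F)cc1` gives 15400 nM, a lower number beyond the scatter. Compound 4 `Cc1ccc(N2C(=O)COc3ccc(-c4cnc(Cl)c(NS(=O)(=O)c5ccc(F)cc5)c4)cc32)cc1` differs from compound 3 by methyl in place of fluoro on an aromatic carbon, para to a large group. Going by the values given here, the one measured step at this place, a 1.1-fold lower number from compound 2 to compound 3 (0.04 log units; within the scatter), put fluoro in place of methoxy and stayed within the scatter. No change beyond the scatter, in either direction, is therefore expected in this assay. The expected step is a 1.1-fold lower number from compound 3 to compound 4 (0.02 log units; within the scatter). For compound 4 the estimated value is 31000 nM, with an expected range from 17000 nM to 50000 nM.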

Compound 4, half-maximal inhibitory concentration: 32600 nM
Compound 4: middle estimate off by 1.1-fold (0.02 log units), on the low side; low and high end bracket the measured number.
By their numbers in this assay, from the lowest: compound 1; then compounds 3, 4 and 2 (each within the scatter of the next).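

With this assay, the 4-fluorophenyl to 4-methylphenyl change gives no change at the digits printed from compound 3 to compound 4 (within the scatter), and methyl in place of methoxy at the same place gives a 1.1-fold lower number from compound 2 to compound 4 (0.04 log units; within the scatter), so fluoro, methoxy and methyl all lie within the scatter of one another here. The only step beyond the scatter among these new ones sits elsewhere, where chloro replaces methoxy: a 2.1-fold higher number from compound 1 to compound 4 (0.33 log units; beyond the scatter). No measurement offered here accounts for either finding.

On these data alone, whether an amine or a carboxylic acid at this position would leave the number just as unmoved remains open.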